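The source may report more compounds than this note shows. Statements on the series, on what has been measured and on what is new or still open speak of the compounds shown alone.

Compound 3 `CC(=O)c1ccc(CNc2ccc(-c3c(N)nc(N)nc3COCc3ccccc3)cc2)cc1` stands second highest of the three numbers in a functional assay on CHOK cells for antagonist activity at growth hormone secretagogue receptor type 1 (Homo sapiens), read by calcium flux; a higher number here means a weaker inhibitor, a lower number a stronger inhibitor: compound 3 gives 10 nM, while compound 2 `Nc1nc(N)c(-c2ccc(NCc3ccc([N+](=O)[O-])cc3)cc2)c(COCc2ccccc2)n1` gives 5.8 nM and compound 1 `CCc1nc(N)nc(N)c1-c1ccc(NCc2ccnc(Cl)c2)cc1` gives 220 nM. Among the measured compounds shown here, the one measured step between neighbours, a 1.7-fold higher number from compound 2 to compound 3 (0.24 log units; within the scatter), swaps one substituent for another without moving the number beyond the scatter. Compound 4 `Nc1nc(N)c(-c2ccc(NCc3ccnc(Cl)c3)cc2)c(COCc2ccccc2)n1` differs from compound 3 by 2-chloropyridin-4-yl in place of 4-acetylphenyl on a saturated chain carbon bound to a nitrogen on an aromatic ring. For the measured compounds named here, no measured step covers this exchange itself; compound 1 carries the same (2-chloropyridin-4-yl)methyl group on a different core and shows a much higher number than compound 3. The number for compound 4 is therefore expected to rise modestly, a 2.5-fold higher number from compound 3 to compound 4 (0.40 log units; beyond the scatter). Compound 4 is estimated at 25 nM, with a range from 7 nM to 90 nM.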

Compound 4, half-maximal inhibitory concentration: 3.6 nM
Compound 4: middle estimate off by 6.9-fold (0.84 log units), on the high side, and the stated range ends above it.
By their numbers in this assay, from the lowest: compounds 4, 2 and 3 (each within the scatter of the next, the first and the last beyond it); then compound 1.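

In this assay, the (2-chloropyridin-4-yl)methyl group of compound 1 proves compatible with a low number once benzyloxy replaces methyl on the saturated chain carbon, a large change of a 61-fold lower number from compound 1 to compound 4 (1.79 log units; beyond the scatter) on the core. At the other position, 2-chloropyridin-4-yl is accepted in place of a substituted phenyl: the step is a 2.8-fold lower number from compound 3 to compound 4 (0.44 log units; beyond the scatter) against 4-acetylphenyl and a 1.6-fold lower number from compound 2 to compound 4 (0.21 log units; within the scatter) against 4-nitrophenyl. No evidence at hand explains these steps. Still open, as far as these compounds go, is how a pyridine ring without the chlorine would compare at this place, and whether an amine or a longer chain could stand in for benzyloxy.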